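The source may report more compounds than this note shows. Statements on the series, on what has been measured and on what is new or still open speak of the compounds shown alone.

Compound 3 `Cc1nn(C)c(Sc2ccccc2)c1/C=N/OCc1ccc(C(=O)OC(C)(C)C)cc1`, with its phenylsulfanyl group, gives 0.13 ug/mL in a functional assay on A549 cells (Homo sapiens) for cytotoxicity; a higher number here means a weaker inhibitor, a lower number a stronger inhibitor; in this assay compound 1 `Cc1nn(C)c(N2CCCC2)c1/C=N/OCc1ccc(C(=O)OC(C)(C)C)cc1` gives 0.13 ug/mL and compound 2 `Cc1nn(C)c(-n2ccnc2)c1/C=N/OCc1ccc(C(=O)OC(C)(C)C)cc1` gives 5.93 ug/mL. Compound 3 thus sits level with compound 1, the two together at the low end of the three numbers, and the change a 46-fold lower number from compound 2 to compound 3 (1.66 log units; beyond the scatter) is the only large one in the set, while no change at the digits printed from compound 1 to compound 3 (within the scatter). The next step, (dimethylamino in place of phenylsulfanyl on an aromatic carbon), gives compound 4 `Cc1nn(C)c(N(C)C)c1/C=N/OCc1ccc(C(=O)OC(C)(C)C)cc1`. Two exchanges at this carbon are known: no change at the digits printed from compound 1 to compound 3 (within the scatter), whereas a 46-fold higher number from compound 1 to compound 2 (1.66 log units; beyond the scatter). Dimethylamino, like the pyrrolidin-1-yl of compound 1, is expected to leave this assay essentially where it stands, so compound 4 is expected to show a 1.5-fold higher number from compound 3 to compound 4 (0.19 log units; within the scatter). The estimate for compound 4 is 0.2 ug/mL, in the range 0.06 ug/mL to 0.8 ug/mL.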

Compound 4, half-maximal inhibitory concentration: 2.76 ug/mL
Compound 4: the middle estimate sits 14-fold (1.14 log units) below what was measured; the measured number lies above the stated range.
By their numbers in this assay, from the lowest: compounds 1 and 3 (each within the scatter of the next); then compound 4; then compound 2.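

Pyrrolidin-1-yl and dimethylamino are not interchangeable at this carbon in this assay, with a 21-fold higher number from compound 1 to compound 4 (1.33 log units; beyond the scatter), so a nitrogen attachment alone does not hold the low number. Phenylsulfanyl and dimethylamino also part sharply, with a 21-fold higher number from compound 3 to compound 4 (1.33 log units; beyond the scatter), while the exchange of 1H-imidazol-1-yl for dimethylamino gives only a 2.1-fold lower number from compound 2 to compound 4 (0.33 log units; beyond the scatter). No evidence in hand accounts for these gaps.

On these data alone, whether the low number depends on the ring of pyrrolidin-1-yl remains open. Piperidin-1-yl, morpholin-4-yl or diethylamino at this carbon would bear on that question.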